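Neopentyl to isobutyl on compound 1

A few compounds are considered here, and "the series" means these few. Any claim that something is new, unique, unknown or untested is made for them only; others in the source may bear on it.

In an ADME assay on a cell-free system (plasma, Rattus norvegicus) for metabolic stability, read by LC-MS, with a stated time of 60 min, tested at 100 uM (on this read-out higher numbers stand for a more stable compound and lower numbers for a less stable compound), compound 1 `Cc1c(OCCCCOc2ccc(F)c(C(=O)O)c2)ccc(C(=O)CC(C)(C)C)c1O` gives 83%. Compound 2 `Cc1c(OCCCCOc2ccc(C(=O)CC(C)(C)C)c(O)c2C)cccc1C(=O)O` gives 89%, within the scatter of compound 1. Compound 3 `Cc1c(OCCCCOc2ccc(C(=O)O)c(Cl)c2)ccc(C(=O)CC2CCCC2)c1O` reads higher at 97%, beyond the scatter of compound 1, but it differs from compound 1 in more than one place, so that gap cannot be assigned to any single change.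

Compound 4 `Cc1c(OCCCCOc2ccc(F)c(C(=O)O)c2)ccc(C(=O)CC(C)C)c1O` differs from compound 1 as follows: hydrogen in place of methyl on a saturated chain carbon bound to three saturated chain carbons. This is hydrogen in place of methyl on a saturated chain carbon bound to three saturated chain carbons, which turns neopentyl to isobutyl.

For the measured compounds named here, only one measured step bears on the series, a number 6 percentage points higher from compound 1 to compound 2 (within the scatter), and it lies within the scatter. It replaces 3-carboxy-4-fluorophenyl, so it leaves the neopentyl group untouched and gives only indirect guidance. Going by the values given here, no measured step alters that group alone. No step beyond the scatter is therefore expected in this assay, and the estimate is a number 4 percentage points higher from compound 1 to compound 4 (within the scatter). For compound 4 the expected value is 87%, with an estimated range of 76% to 98%.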

Compound 4, percent of the compound remaining: 101%
Compound 4: the middle estimate sits 14 percentage points below what was measured; measured number outside the range, above it.
By their numbers in this assay, from the lowest: compounds 1, 2, 3 and 4 (each within the scatter of the next, the first and the last beyond it).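

Neopentyl to isobutyl now gives a direct reading at this position: in this assay, hydrogen in place of methyl gives a number 18 percentage points higher from compound 1 to compound 4 (beyond the scatter). For the compounds shown here, the only earlier step between compounds differing in one place replaces 3-carboxy-4-fluorophenyl and stays within the scatter, so this is the first step to go beyond it. The read-out therefore responds to the loss of one methyl, a single carbon, on a saturated chain carbon bound to three saturated chain carbons.

The data shown give no explanation for this step. Open questions are whether the same change carries over to the 3-carboxy-2-methylphenyl compounds, and how an ethyl group or a straight propyl chain would read in this place in this assay.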